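The source may report more compounds than this note shows. Statements on the series, on what has been measured and on what is new or still open speak of the compounds shown alone.

Compounds measured so far in a functional assay for inhibition of nuclear factor NF-kappa-B complex (Homo sapiens); a higher number here means a weaker inhibitor, a lower number a stronger inhibitor:

Compound 1 `COc1ccc2c(c1)OC(c1cc(OC)c(OC)c(OC)c1)C(C(=O)N1CCCCC1)=C2` sits at a limit, > 50000 nM.
Compound 2 `COc1ccc2c(c1)OC(c1cc(OC)c(OC)c(OC)c1)C(C(=O)Nc1ccccc1)=C2` gives 17500 nM.
Compound 3 `COc1ccc2c(c1)OC(c1cc(OC)c(OC)c(OC)c1)C(C(=O)OCCc1ccccc1)=C2` gives 16200 nM.

Compound 3 stands lowest of the two numbers; compound 2 is the nearest, and the step of a 1.1-fold lower number from compound 2 to compound 3 (0.03 log units; within the scatter) lies within the scatter, so the two cannot be ordered. Compound 1 contributes only a limit (the limit of > 50000 nM in this assay, at which 1 of the 3 values shown sits).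

Compound 4 `CCOCC1=Cc2ccc(OC)cc2OC1c1cc(OC)c(OC)c(OC)c1` differs from compound 3 by ethoxymethyl in place of phenethyloxycarbonyl on a double-bonded ring carbon. The measured steps of an at least 2.8-fold lower number from compound 1 to compound 2 (0.45 log units; beyond the scatter) and an at least 3.0-fold lower number from compound 1 to compound 3 (0.48 log units; beyond the scatter) each exchange the group on the carbonyl carbon while the carbonyl itself stays; the step of a 1.1-fold lower number from compound 2 to compound 3 (0.03 log units; within the scatter) shows that anilino and phenethyloxy on that carbonyl are interchangeable within the scatter. Going by the values given here, no measured step removes the carbonyl or replaces it with a short ether chain, so these steps bear on the change to compound 4 only loosely. With one of three measured values already at a limit, the expectation for compound 4 is a step of a 1.9-fold higher number from compound 3 to compound 4 (0.27 log units; within the scatter) toward a higher number, with the risk that only a limit is reported. Compound 4 is estimated at 30000 nM, in the range 8000 nM to 100000 nM.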

Compound 4, half-maximal inhibitory concentration: 21300 nM
Compound 4: the middle estimate sits 1.4-fold (0.15 log units) above what was measured, and the stated range covers the measured number.
By their numbers in this assay, from the lowest: compounds 3, 2 and 4 (each within the scatter of the next). At a limit, above all of these: compound 1.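

In this assay the carbonyl on this double-bonded ring carbon can go without a measurable loss, as ethoxymethyl in place of phenethyloxycarbonyl gives a 1.3-fold higher number from compound 3 to compound 4 (0.12 log units; within the scatter) despite also removing the aromatic ring of the leaving group. Against the anilide the same holds, with a 1.2-fold higher number from compound 2 to compound 4 (0.09 log units; within the scatter) for ethoxymethyl in place of phenylcarbamoyl, so an ether chain, an ester and an anilide at this place cannot be told apart, while the (piperidin-1-yl)carbonyl compound remains separate with an at least 2.3-fold lower number from compound 1 to compound 4 (0.37 log units; beyond the scatter) as its step. Compound 1 is a limit, not a number: the limit of > 50000 nM in this assay, at which 1 of the 4 values shown sits.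

As far as these compounds go, whether a hydroxymethyl group, a carboxylic acid or an aminomethyl group at this place would stay in the same range remains open. Also open, from the compounds shown here alone, is whether any group here can reach numbers clearly lower than those of compounds 2, 3 and 4.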